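Pyrimidin-2-yl for pyridin-2-yl on the piperazine-type nitrogen

The source may report more compounds than this note shows. Statements on the series, on what has been measured and on what is new or still open speak of the compounds shown alone.

Measured in a functional assay on PC-3 cells (Homo sapiens) for inhibition, read by MTT assay, with a stated time of 72 h; a higher number here means a weaker inhibitor, a lower number a stronger inhibitor:
- Compound 1 `FC(F)(F)c1ccc(CSc2nc(N3CCNCC3)cc(C(F)(F)F)n2)cc1`: 15900 nM
- Compound 2 `FC(F)(F)c1ccc(CSc2nc(N3CCN(c4ccccn4)CC3)cc(C(F)(F)F)n2)cc1`: > 50000 nM

Compound 2 stands at > 50000 nM, which is a limit of the assay and not a number. Compound 3 `FC(F)(F)c1ccc(CSc2nc(N3CCN(c4ncccn4)CC3)cc(C(F)(F)F)n2)cc1` differs from compound 2 by pyrimidin-2-yl in place of pyridin-2-yl on an amine nitrogen in a ring. For the measured compounds named here, one measured step bears on this, an at least 3.1-fold higher number from compound 1 to compound 2 (0.49 log units; beyond the scatter), with pyridin-2-yl in place of hydrogen. Going by the values given here, no measured step exchanges one aromatic ring for another. In this assay the estimated step of a number no higher from compound 2 to compound 3 (the limit leaves the size open) is expected to stay within the scatter, with no firm direction. The expected value for compound 3 is 50000 nM, with an estimated range of 22000 nM to 100000 nM.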

Compound 3, half-maximal inhibitory concentration: > 50000 nM
Compound 3 was reported as a limit; the forecaster's own chance of this, stated with the estimate: 60%; the middle value sits exactly at the limit.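

In this assay, pyrimidin-2-yl on the amine nitrogen in a ring gives an at least 3.1-fold higher number from compound 1 to compound 3 (0.49 log units; beyond the scatter), so the loss seen with pyridin-2-yl on this nitrogen also holds for a second aromatic ring. The value of compound 3, > 50000 nM, is a limit of the assay and not a number. The exchange of pyridin-2-yl for pyrimidin-2-yl cannot be read, because both compounds sit at that limit: the limit of > 50000 nM in this assay, at which 2 of the 3 values shown sit.

As far as these compounds go, how far compound 2 and compound 3 lie past the limit stays open. Also open, from the compounds shown here alone, is whether a non-aromatic group on this nitrogen, such as methyl or acetyl, would keep or better the result of compound 1.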